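The source may hold more compounds than are shown below. What is called first, only, known or untested is meant among the compounds shown, and "the series" means these compounds.

Measured compounds in a functional assay on SW-620 cells (Homo sapiens) for antiproliferative activity, read by MTT assay, with a stated time of 72 h; a higher number here means a weaker inhibitor, a lower number a stronger inhibitor:
compound 1 `O=c1nc2oc(CCCCl)c(C#CCCCCl)c2cn1Cc1cn(Cc2ccccc2)nn1` gives 33900 nM
compound 2 `CCCCCCc1cc2cn(Cc3cn(Cc4ccccc4)nn3)c(=O)nc2o1` gives 93500 nM
compound 3 `O=c1nc2oc(CCCCl)cc2cn1Cc1cn(Cc2ccccc2)nn1` gives 75500 nM

Compound 3 stands second highest of the three numbers. Its nearest neighbour is compound 2, within the scatter (a 1.2-fold lower number from compound 2 to compound 3 (0.09 log units; within the scatter)), while compound 1 sits further off (a 2.2-fold higher number from compound 1 to compound 3 (0.35 log units; beyond the scatter)). Compound 4 `O=c1nc2oc(C3CC3)cc2cn1Cc1cn(Cc2ccccc2)nn1` is not yet measured; it differs from compound 3 in one place: cyclopropyl in place of 3-chloropropyl on an aromatic carbon.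

Going by the values given here, two measured steps bear on this change. The step from compound 2 to compound 3 exchanges one chain for another at the same aromatic carbon and leaves the number essentially where it was. The step from compound 1 to compound 3 removes a substituent from a different aromatic carbon and gives a modest rise. Among the compounds with values here, neither step replaces a chain with a ring, so the present change has no direct precedent in the set; the closest parallel, the exchange of chains at this carbon, indicates that what sits there has so far mattered little. A step of small size, not beyond the scatter, is therefore expected: a 1.1-fold higher number from compound 3 to compound 4 (0.03 log units; within the scatter). For compound 4 the estimate in this assay is 80000 nM, with a range from 30000 nM to 200000 nM.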

Compound 4, half-maximal inhibitory concentration: 54700 nM
Beside the measured number, compound 4's estimate is 1.5-fold (0.17 log units) above it, and the stated range covers the measured number.
By their numbers in this assay, from the lowest: compounds 1, 4, 3 and 2 (each within the scatter of the next, the first and the last beyond it).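

In this assay, going by these compounds alone, a ring appears for the first time on this aromatic carbon next to the ring oxygen, yet cyclopropyl in place of 3-chloropropyl gives only a step within the scatter (a 1.4-fold lower number from compound 3 to compound 4 (0.14 log units; within the scatter)), and cyclopropyl in place of hexyl does the same (a 1.7-fold lower number from compound 2 to compound 4 (0.23 log units; within the scatter)). Within the data shown here, with the earlier chain exchange (a 1.2-fold lower number from compound 2 to compound 3 (0.09 log units; within the scatter)), the hexyl, 3-chloropropyl and cyclopropyl groups of compound 2, compound 3 and compound 4 now form a set of three in which no printed step at this carbon lies beyond the scatter, so neither chain nor ring separates these compounds in this assay. No measurement at hand offers an explanation for this result.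

Still open, on these data alone, is whether an amine, a carboxylic acid or a cyclohexyl ring on this carbon would give a step beyond the scatter. Among these compounds, also open is whether cyclopropyl would give the same result alongside the 5-chloropent-1-yn-1-yl group of compound 1, whose replacement by hydrogen gives the only step here beyond the scatter (a 2.2-fold higher number from compound 1 to compound 3 (0.35 log units; beyond the scatter)).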